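The compounds below may be only part of what the source reports. "The series", "measured", "known", "first", "only" and "open" are said of these compounds alone.

Two cores are compared in an assay on cells for inhibition of Palmitoleoyl-protein carboxylesterase NOTUM variant C330S (Homo sapiens), read by fluorescence, with a stated time of 40 min; a lower number here means a stronger inhibitor, a higher number a weaker inhibitor. Compound 1 `O=C(O)C1CCN(c2ccccc2Cl)C1` gives 19000 nM, the highest of the three numbers. Compound 2 `Cc1cc(C(=O)O)c(C)n1-c1ccccc1Cl` gives 2300 nM, and compound 3 `Cc1cc(C(=O)O)c(C)n1-c1cc(Cl)ccc1Cl` gives 1700 nM. The difference between the core of compound 1 and the core of compound 2 is not broken down here. From compound 2 to compound 3 the change is chloro in place of hydrogen on an aromatic carbon and it made a 1.4-fold lower number from compound 2 to compound 3 (0.13 log units; within the scatter). Compound 4 `O=C(O)C1CCN(c2c(Cl)cccc2Cl)C1` is not yet measured in this assay; from compound 1 it differs by chloro in place of hydrogen on an aromatic carbon, the same kind of change, though here the place is ortho to a group of 8 heavy atoms and meta to a chloro group, where in compound 3 it is meta to a large group and para to a chloro group. Because a 1.4-fold lower number from compound 2 to compound 3 (0.13 log units; within the scatter) lies within the scatter, only a small step is expected, estimated as a 1.5-fold lower number from compound 1 to compound 4 (0.16 log units; within the scatter). For compound 4 in this assay the estimate is 13000 nM, with a range from 5000 nM to 40000 nM.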

Compound 4, half-maximal inhibitory concentration: 26000 nM
Estimate against measurement, compound 4: 2.0-fold (0.30 log units) below, within the range that was stated.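

In this assay, chloro in place of hydrogen on an aromatic carbon gives a 1.4-fold higher number from compound 1 to compound 4 (0.14 log units; within the scatter), a small step on the core of compound 1. The same change gives only small steps on both cores, and the two steps do not differ: the same change on two cores in this assay, a 1.4-fold lower number (0.13 log units; within the scatter) from compound 2 to compound 3 and a 1.4-fold higher number (0.14 log units; within the scatter) from compound 1 to compound 4, 1.9-fold (0.27 log units) apart, within the scatter of two such steps

This does not show that the step would be the same at every place on the aromatic ring, since the chloro enters at a different place on each core, and two small steps give no direction for the change. The compounds shown leave open whether another group at these places, such as methoxy, a nitrile or an amine, gives a step beyond the scatter on either core. Also open, as far as these compounds go, is what an amide in place of the carboxylic acid would do.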